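This account rests on a few compounds, and the source may have more. Where it says the series, first, only, none or still open, it means among the compounds named here.

The measured compounds, with their values in an assay on HEK293 cells for inhibition of Voltage-dependent T-type calcium channel subunit alpha-1G (Homo sapiens), read by patch clamp; a higher number here means a weaker inhibitor, a lower number a stronger inhibitor:

Compound 1, `CCCc1nc(-c2ccccc2)c(CNCCCN2CCN(c3cccc(C)c3)CC2)o1`: 1190 nM
Compound 2, `CCCc1nc(-c2ccccc2)c(CNCCN2CCN(c3ccc(Cl)cc3)CC2)o1`: 2820 nM
Compound 3, `CCCc1nc(-c2ccccc2)c(CNCCN2CCN(c3ccccc3C)CC2)o1`: 4300 nM

Among these three, compound 1 gives the lowest number in this assay, and its gaps to compound 2 and to compound 3 both lie beyond the usual scatter. Compound 4, `CCCc1nc(-c2ccccc2)c(CNCCCN2CCN(c3ccc(C)cc3)CC2)o1`, has not been measured. It differs from compound 1 by a single change: 4-methylphenyl in place of 3-methylphenyl on an amine nitrogen in a ring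

Among the compounds with values here, the one measured step that bears on a change of this kind is a 1.5-fold higher number from compound 2 to compound 3 (0.18 log units; within the scatter). That step swapped one ring substituent for another at the same place on a core that differs from that of compound 1, and it stayed within the scatter. Moving a methyl group from one position of the ring to another is a smaller change than that, so no step beyond the scatter is expected here; the number for compound 4 is expected to stay close to that of compound 1.

The estimate for compound 4 in this assay is 1500 nM, with a range from 600 nM to 4000 nM, which amounts to an expected step of a 1.3-fold higher number from compound 1 to compound 4 (0.10 log units; within the scatter).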

Compound 4, half-maximal inhibitory concentration: 130000 nM
Compound 4: the middle estimate sits 87-fold (1.94 log units) below what was measured, outside the stated range (above it).
By their numbers in this assay, from the lowest: compound 1; then compounds 2 and 3 (each within the scatter of the next); then compound 4.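

In this assay, shifting one methyl group around the phenyl ring gives a 110-fold higher number from compound 1 to compound 4 (2.04 log units; beyond the scatter), even though 3-methylphenyl and 4-methylphenyl have identical atom counts and sit on the same amine nitrogen of the six-membered ring. The earlier swap at this place, a 1.5-fold higher number from compound 2 to compound 3 (0.18 log units; within the scatter), gave no hint of this, and the new step shows that here the position of a single methyl group can matter far more than the atoms it contains. Nothing available explains why this shift has so large an effect.

From the compounds shown here alone, it remains open whether a methoxy group or a fluorine in place of the methyl of compound 4 would give a similarly high number. Also unresolved is how 2-methylphenyl would behave on the otherwise unchanged structure of compound 1.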